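The source may hold more compounds than are shown below. What is called first, only, known or untested is meant among the compounds shown, and "the series" means these compounds.

Working notes on the series. Compound 1 `Cc1nc(-c2ccccc2)sc1C(=O)CSc1nc(-c2ccccc2)c(C#N)c(=O)[nH]1` carries the shared core with an unsubstituted phenyl on the pyrimidinone side; in a functional assay on U-87MG ATCC cells for antiproliferative activity against U-87 MG (Homo sapiens), read by MTT assay, with a stated time of 48 h, tested at 5 uM (on this read-out higher numbers stand for a weaker effect at the one concentration tested and lower numbers for a stronger effect), compound 1 gives 92.1%. Compound 2 `COc1ccc(-c2nc(SCC(=O)c3sc(-c4ccccc4)nc3C)[nH]c(=O)c2C#N)cc1OC` gives 80.8% in this assay, the step being a number 11.3 percentage points lower from compound 1 to compound 2 (beyond the scatter). Within the data shown here, compound 3 `COc1cccc(-c2nc(SCC(=O)c3sc(-c4ccccc4)nc3C)[nH]c(=O)c2C#N)c1` gives 99%, the highest of the three numbers so far; the steps that lead to it are a number 6.9 percentage points higher from compound 1 to compound 3 (within the scatter) and a number 18.2 percentage points higher from compound 2 to compound 3 (beyond the scatter), so compound 3 and compound 1 cannot be told apart, while compound 2 sits apart from both.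

Compound 4 `Cc1nc(-c2ccccc2)sc1C(=O)CSc1nc(-c2cccc(Cl)c2)c(C#N)c(=O)[nH]1` has not yet been measured. It differs from compound 3 by chloro in place of methoxy on an aromatic carbon. Among the measured compounds shown here, no measured step exchanges methoxy for chloro, so the only bearing comes from the methoxy steps already seen, a number 6.9 percentage points higher from compound 1 to compound 3 (within the scatter) and a number 18.2 percentage points higher from compound 2 to compound 3 (beyond the scatter), which move the read-out only modestly or not beyond scatter. For compound 4 a step of about a number 5 percentage points lower from compound 3 to compound 4 (within the scatter) is therefore expected, within the scatter. Compound 4 is estimated at 94%, range 80% to 102%.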

Compound 4, a percentage reported as activity, at one concentration (the size of the read-out at that concentration, not a potency): 86.9%
For compound 4 the middle estimate is 7.1 percentage points above the measured one; measured number inside the range.
By their numbers in this assay, from the lowest: compounds 2, 4, 1 and 3 (each within the scatter of the next, the first and the last beyond it).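

Among these compounds, the exchange of 3-methoxyphenyl for 3-chlorophenyl is the first single-group change at this place, meta to a large group, to exceed the scatter in this assay with a number 12.1 percentage points lower from compound 3 to compound 4 (beyond the scatter) and so a modest move towards a stronger effect. Chloro does not separate from hydrogen, with a number 5.2 percentage points lower from compound 1 to compound 4 (within the scatter) as the step, and compound 4 also cannot be told from the 3,4-dimethoxyphenyl analogue, with a number 6.1 percentage points higher from compound 2 to compound 4 (within the scatter) as the step, so the gain appears only against methoxy. No independent data bear on the origin of this step.

On these data alone, whether an amine, a carboxylic acid or a longer chain such as butoxy at this place would move the read-out further remains open. Also open, as far as these compounds go, is whether chloro elsewhere on this ring would behave in the same way.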